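The source may hold more compounds than are shown below. What is called first, only, known or untested is meant among the compounds shown, and "the series" means these compounds.

Measured compounds in an assay on CHO cells for displacement of a labelled ligand from adenosine receptor A2b (Homo sapiens), read by radioligand binding; on this read-out lower numbers stand for stronger inhibition and higher numbers for weaker inhibition:

Compound 1 `O=c1oc2c(O)cccc2cc1-c1ccccc1`: compound 1 gives > 30000 nM, which is a limit of the assay and not a number.
Compound 2 `O=c1oc2c(O)c(O)ccc2cc1-c1ccccc1`: compound 2 gives > 30000 nM, again a limit.
Compound 3 `O=c1oc2c(O)cccc2cc1-c1ccc(O)c(O)c1`: compound 3 gives > 30000 nM, also a limit.

Compound 2 arises from compound 1 by hydroxy in place of hydrogen on an aromatic carbon. Because both ends sit on (the limit of > 30000 nM in this assay, at which 3 of the 3 values shown sit), the step that the two limits leave unreadable from compound 1 to compound 2 is unreadable. The difference between the cores of compound 1 and compound 3 is not broken down here. Compound 4 `O=c1oc2c(O)c(O)ccc2cc1-c1ccc(O)c(O)c1` is not yet measured in this assay; it arises from compound 3 by hydroxy in place of hydrogen on an aromatic carbon, the same change as from compound 1 to compound 2, with the surroundings of the place described in the same words. The step from compound 3 to compound 4 is expected to be small, a number no higher from compound 3 to compound 4 (the limit leaves the size open), because the limit of > 30000 nM in this assay, at which 3 of the 3 values shown sit, leaves no readable movement anywhere in the series. Compound 4 is therefore expected near 30000 nM, between 10000 nM and 100000 nM, most likely reported only as a limit.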

Compound 4, inhibition constant: > 30000 nM
Compound 4: no number, only a limit; the forecaster's own chance of this, stated with the estimate: 85%; the middle value sits exactly at the limit.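

No step can be read from compound 3 to compound 4, because both ends sit on the same limit: the limit of > 30000 nM in this assay, at which 4 of the 4 values shown sit.

The compounds shown leave open how far any of the four lies beyond that limit, and whether hydroxy in place of hydrogen moves the read-out at all.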